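The source may report more compounds than this note shows. Statements on the series, on what has been measured and on what is new or still open speak of the compounds shown alone.

Measured compounds:
compound 1, `Nc1ccc(-c2cc(=O)c3c(N)c(F)cc(F)c3o2)cc1F`, 40 nM
compound 2, `Cc1c(F)c(N)c2c(=O)cc(-c3ccc(N)c(F)c3)oc2c1F`, 13 nM
compound 3, `Nc1ccc(-c2cc(=O)c3c(N)c(F)c(N)c(F)c3o2)cc1F`, 7.7 nM

These three compounds were tested in a functional assay on MCF7 cells (Homo sapiens) for cytotoxicity, read by neutral red uptake, with a stated time of 3 days; on this read-out higher numbers stand for weaker inhibition and lower numbers for stronger inhibition. Compound 3 gives the lowest number of the three, but its nearest neighbour is compound 2, and the gap a 1.7-fold lower number from compound 2 to compound 3 (0.23 log units; within the scatter) lies within the scatter, so the two cannot be ranked against each other. Only compound 1 stands clearly apart, with a 5.2-fold lower number from compound 1 to compound 3 (0.72 log units; beyond the scatter).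

Compound 4 is `NCc1c(F)c(N)c2c(=O)cc(-c3ccc(N)c(F)c3)oc2c1F`, not yet measured. It differs from compound 3 in one place: aminomethyl in place of amino on an aromatic carbon.

Going by the values given here, none of the measured steps concerns aminomethyl itself. The same aromatic carbon has carried hydrogen, methyl and amino: the step of a 3.1-fold lower number from compound 1 to compound 2 (0.49 log units; beyond the scatter) and the step of a 5.2-fold lower number from compound 1 to compound 3 (0.72 log units; beyond the scatter) both lowered the number modestly, while a 1.7-fold lower number from compound 2 to compound 3 (0.23 log units; within the scatter) stayed within the scatter. Both a one-carbon group and a one-nitrogen group at this place therefore behave alike, and aminomethyl combines features of both. The step of a 1.6-fold higher number from compound 3 to compound 4 (0.19 log units; within the scatter) in this assay is thus expected to stay within the scatter, with at most a slight rise in the number.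

The estimate for compound 4 is 12 nM, with a likely range from 4 nM to 40 nM.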

Compound 4, half-maximal inhibitory concentration: 26 nM
The estimate for compound 4 lay 2.2-fold (0.34 log units) below the measured number, within the range that was stated.
By their numbers in this assay, from the lowest: compounds 3, 2, 4 and 1 (each within the scatter of the next, the first and the last beyond it).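

In this assay, going by these compounds alone, the step of a 3.4-fold higher number from compound 3 to compound 4 (0.53 log units; beyond the scatter) is the first evidence that this aromatic carbon, ortho to two fluoro groups, tells substituents apart beyond the scatter when amino is the reference, since methyl and amino could not be separated there. Aminomethyl also fails to separate from the two groups it might have resembled: the step of a 2.0-fold higher number from compound 2 to compound 4 (0.30 log units; within the scatter) leaves it level with methyl, and the step of a 1.5-fold lower number from compound 1 to compound 4 (0.19 log units; within the scatter) leaves it level with hydrogen. Methyl and amino each lie clearly below hydrogen at this place, so compound 4 goes against any reading that every group tried here lowers the number beyond the scatter, and adding an amino group to the methyl does not bring compound 4 to the level of compound 3.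

The compounds shown leave open how a hydroxymethyl group or a longer chain such as aminoethyl would read on this carbon. Nothing available here bears on what lies behind the gap between amino and aminomethyl.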